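Estimating a pyridine swap on compound 1

The source may report more compounds than this note shows. Statements on the series, on what has been measured and on what is new or still open speak of the compounds shown alone.

compound 1 `CNC(=O)[C@@H]1CCCN1S(=O)(=O)c1ccc(Cl)c(COc2cccc3c(-n4ccnc4)cc(C)nc23)c1Cl`: 267 mL/min/kg
compound 2 `Cc1cc(C(F)(F)F)c2cccc(OCc3c(Cl)ccc(S(=O)(=O)N4CCCC4)c3Cl)c2n1`: 967 mL/min/kg
compound 3 `Cc1cc(C(F)(F)F)c2cccc(OCc3c(Cl)ccc(S(=O)(=O)N4C[C@@H](C)O[C@@H](C)C4)c3Cl)c2n1`: 933 mL/min/kg

In an ADME assay on microsomes (Mus musculus) for metabolic stability (a lower number here means slower removal, a higher number faster removal of the compound), compound 1 has the lowest number, and its gap to each of the other two lies beyond the scatter. Compound 4 `CNC(=O)[C@@H]1CCCN1S(=O)(=O)c1ccc(Cl)c(COc2cccc3c(-c4cccnc4)cc(C)nc23)c1Cl` keeps the rest of compound 1 and changes one group: pyridin-3-yl in place of 1H-imidazol-1-yl on an aromatic carbon. Pyridin-3-yl stands in place of 1H-imidazol-1-yl on an aromatic carbon, opposite the ring nitrogen.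

For the measured compounds named here, the only measured single change is a 1.0-fold lower number from compound 2 to compound 3 (0.02 log units; within the scatter). It lies on a sulfonyl sulfur, not at this place, so it offers little guidance here. Compound 2 and compound 3 also differ from compound 1 in more than one place, so their higher numbers cannot be assigned to any single group. Going by the values given here, no measured step tests this swap, so no clear direction can be expected, and a change within the scatter is the cautious expectation. The expected change is a 1.1-fold higher number from compound 1 to compound 4 (0.05 log units; within the scatter). Compound 4 is estimated at 300 mL/min/kg, with an expected range from 130 mL/min/kg to 650 mL/min/kg.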

Compound 4, clearance: 700 mL/min/kg
For compound 4 the middle estimate is 2.3-fold (0.37 log units) below the measured one; the measured number lies above the stated range.
By their numbers in this assay, from the lowest: compound 1; then compounds 4, 3 and 2 (each within the scatter of the next).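

For the compounds shown here, this is the first measured step at this place, on an aromatic carbon opposite the ring nitrogen, and in this assay it shows that the ring held there matters: the swap to pyridin-3-yl gives a 2.6-fold higher number from compound 1 to compound 4 (0.42 log units; beyond the scatter) and lies beyond the scatter. The rest of compound 1 stays unchanged in compound 4, so this rise, unlike the higher numbers of compound 2 and compound 3, can be assigned to a single group. No measurement shown explains why the one ring is cleared faster than the other.

The compounds shown leave open how a phenyl ring or a simple amine at this place would compare with 1H-imidazol-1-yl. As far as these compounds go, it also stays open whether the same swap would give a step of similar size with another group on the sulfonyl sulfur, such as pyrrolidin-1-yl.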